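Swapping isopropoxy for methoxy on the shared core

This account rests on a few compounds, and the source may have more. Where it says the series, first, only, none or still open, it means among the compounds named here.

Values in a toxicity assay on Huh-7.5 cells (Homo sapiens) for inhibition, read by MTT assay, with a stated time of 96 h; a higher number here means that more compound is tolerated, a lower number that less compound is tolerated:
- Compound 1 `CCC(=O)Nc1cc(C(=O)Nc2ccc(N3CCN(C)CC3)cc2)ccc1OC`: > 200000 nM
- Compound 2 `CCC(=O)Nc1cc(C(=O)Nc2ccc(CN3CCN(C)CC3)c(C(F)(F)F)c2)ccc1OC(C)C`: 15300 nM
- Compound 3 `CC(C)Oc1ccc(C(=O)Nc2ccc(CN3CCN(C)CC3)c(C(F)(F)F)c2)cc1NC(=O)C(C)Br`: 8700 nM

The entry for compound 1 is a limit of the assay, not a number. That leaves compound 2 with one numeric neighbour, and the two sit together: a 1.8-fold lower number from compound 2 to compound 3 (0.25 log units; within the scatter).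

Compound 4 `CCC(=O)Nc1cc(C(=O)Nc2ccc(CN3CCN(C)CC3)c(C(F)(F)F)c2)ccc1OC` has not yet been measured. It differs from compound 2 in one place: methyl in place of isopropyl on an oxygen on an aromatic ring. Among the measured compounds shown here, no measured step covers this change. For the measured compounds named here, the one available step lies elsewhere on the structure and stays within the scatter, so only a small change is expected, an estimated 1.2-fold higher number from compound 2 to compound 4 (0.07 log units; within the scatter). Compound 4 is estimated at 18000 nM, with an expected range of 8000 nM to 45000 nM.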

Compound 4, half-maximal cytotoxic concentration: 35300 nM
The estimate for compound 4 lay 2.0-fold (0.29 log units) below the measured number; the range from low to high includes it.
By their numbers in this assay, from the lowest: compounds 3 and 2 (each within the scatter of the next); then compound 4. At a limit, above all of these: compound 1.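

Among the compounds shown here, this is the first measured change at the oxygen on the aromatic ring: in this assay, the change from isopropoxy to methoxy gives a 2.3-fold higher number from compound 2 to compound 4 (0.36 log units; beyond the scatter) and so moves the tolerated concentration modestly upward. For the compounds shown here, the one earlier step, elsewhere on the structure, stayed within the scatter, so this position shows an effect that step did not. Nothing measured here explains the size of this step. Still open, going by these compounds, is how an ethoxy group or a free hydroxyl on this oxygen would compare, and whether the same swap would act alike with the bromo group of compound 3 present.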